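Isopropyl for 2-acetamidoethyl on the amine nitrogen

A few compounds are considered here, and "the series" means these few. Any claim that something is new, unique, unknown or untested is made for them only; others in the source may bear on it.

Measured in a functional assay on HT-29 cells (Homo sapiens) for inhibition, read by MTT assay, with a stated time of 72 h; a higher number here means a weaker inhibitor, a lower number a stronger inhibitor
compound 1 `COc1cc(Oc2cccc(Nc3ccccc3)c2)cc(OC)c1CNCCNC(C)=O` gives 3960 nM
compound 2 `COc1ccc([C@@H](C)NCc2c(OC)cc(Oc3cccc(Nc4ccccc4)c3)c(OC)c2OC)cc1` gives 1630 nM

Only these two values are available so far. Compound 1 holds the higher number of the two, which makes it the weaker inhibitor of the pair, and the gap down to compound 2 lies beyond the scatter.

Compound 3 `COc1cc(Oc2cccc(Nc3ccccc3)c2)cc(OC)c1CNC(C)C` has not yet been measured. It differs from compound 1 by isopropyl in place of 2-acetamidoethyl on an amine nitrogen, with isopropyl in place of 2-acetamidoethyl on an amine nitrogen. Within the data shown here, no measured pair shows a change at this place, so the expectation rests on little. Among the measured compounds shown here, the one guide is the narrow spread of the two known numbers, with compound 1 at 3960 nM and compound 2 at 1630 nM. A modest move to a lower number is therefore expected in this assay, one that may stay within the scatter, and the opposite direction cannot be ruled out. The expected change is a 1.6-fold lower number from compound 1 to compound 3 (0.20 log units; within the scatter) in size. Compound 3 is estimated at 2500 nM, with an expected range from 800 nM to 7500 nM.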

Compound 3, half-maximal inhibitory concentration: > 20000 nM
Compound 3: a limit, no number; the forecaster's own chance of this, stated with the estimate: 5%; middle value at least 8.0-fold (0.90 log units) from the limit.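

In this assay compound 3 gives > 20000 nM as a limit of the assay and not as a number. Isopropyl in place of 2-acetamidoethyl on the amine nitrogen gives an at least 5.0-fold higher number from compound 1 to compound 3 (0.70 log units; beyond the scatter) on an otherwise unchanged core, which is the first direct reading at this position and shows that the group on this nitrogen has a clear effect on the read-out in this pair. The step is a lower bound, and its full size cannot be read from this result: the limit of > 20000 nM in this assay, at which 1 of the 3 values shown sits.

The compounds shown do not tell whether the difference lies with the acetamide unit or with the length of the chain, since the change removes both at once; a 2-aminoethyl group, a 2-hydroxyethyl group or a longer chain ending in an acetamide would separate the two. Also open, going by these compounds, is whether a carboxylic acid at the chain end, or an ethyl or a tert-butyl group directly on the nitrogen, would give a value in this assay that can be read as a number.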